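The source may report more compounds than this note shows. Statements on the series, on what has been measured and on what is new or still open speak of the compounds shown alone.

Compound 1 `CCn1c(C(=O)NCCNC(=O)OC(C)(C)C)ccc1C(CC)(CC)c1ccc(OCS(=O)(=O)c2ccccc2)c(C)c1` carries an amide whose nitrogen bears a 2-((tert-butoxycarbonyl)amino)ethyl group. In a functional assay on PC-3 cells (Homo sapiens) for antiproliferative activity, read by MTT assay, with a stated time of 24 h (on this read-out higher numbers stand for weaker inhibition and lower numbers for stronger inhibition), compound 1 gives > 50000 nM, which is a limit of the assay and not a number (the limit of > 50000 nM in this assay, at which 1 of the 3 values shown sits). Compound 2 `CCn1c(C(=O)N[C@@H](CO)C(C)C)ccc1C(CC)(CC)c1ccc(OCS(=O)(=O)c2ccccc2)c(C)c1` gives 10600 nM in this assay, and compound 3 `CCn1c(C(=O)NCC(=O)O)ccc1C(CC)(CC)c1ccc(OCS(=O)(=O)c2ccccc2)c(C)c1` gives 30100 nM. The measured steps are an at least 4.7-fold lower number from compound 1 to compound 2 (0.67 log units; beyond the scatter), an at least 1.6-fold lower number from compound 1 to compound 3 (0.22 log units; that floor lies within the scatter) and a 2.8-fold higher number from compound 2 to compound 3 (0.45 log units; beyond the scatter). Compound 4 `CCn1c(C(=O)N[C@@H](CCC(=O)O)C(=O)O)ccc1C(CC)(CC)c1ccc(OCS(=O)(=O)c2ccccc2)c(C)c1` differs from compound 1 by 1,3-dicarboxypropyl in place of 2-((tert-butoxycarbonyl)amino)ethyl on an amide-type nitrogen. The step from compound 1 to compound 3, which also brings in a carboxy group, bears most closely on it and was an at least 1.6-fold lower number from compound 1 to compound 3 (0.22 log units; that floor lies within the scatter), so compound 4 is expected to move an at least 1.4-fold lower number from compound 1 to compound 4 (0.15 log units; that floor lies within the scatter). Compound 4 is therefore estimated at 35000 nM, in a range from 12000 nM to 100000 nM.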

Compound 4, half-maximal inhibitory concentration: > 50000 nM
Compound 4: only a limit was reported; the forecaster's own chance of this, stated with the estimate: 40%; middle value at least 1.4-fold (0.15 log units) away from the limit.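

In this assay, the 1,3-dicarboxypropyl group of compound 4 gives an at least 4.7-fold higher number from compound 2 to compound 4 (0.67 log units; beyond the scatter) when it replaces the 1-(hydroxymethyl)-2-methylpropyl group on the amide-type nitrogen, so this change moves the number up beyond the scatter. Adding 2-carboxyethyl to the chain of compound 3 gives an at least 1.6-fold higher number from compound 3 to compound 4 (0.22 log units; that floor lies within the scatter), and this floor lies within the scatter, so the added carboxy group shows no readable effect. Compound 1 and compound 4 both sit at a limit of the assay, so the step between them cannot be read.

On these data alone, it stays open whether a free amine on the ethyl chain of compound 1, or a longer chain ending in a hydroxyl group, would give a readable number at this nitrogen.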